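A few compounds are considered here, and "the series" means these few. Any claim that something is new, unique, unknown or untested is made for them only; others in the source may bear on it.

In a physicochemical assay for solubility (a higher number here means a more soluble compound, a lower number a less soluble compound), compound 2 (`Cc1nc(C)c(COC(=O)N[C@@H](C(=O)Oc2ccc(-c3cc(=O)c4c(O)c(O)c(O)cc4o3)cc2)C(C)C)nc1C`) gives 252 ug/mL and stands highest of the two measured compounds. Compound 1 (`Cc1nc(C)c(C(=O)N[C@H](CC(C)C)C(=O)Oc2ccc(-c3cc(=O)c4c(O)c(O)c(O)cc4o3)cc2)nc1C`) gives 26 ug/mL there, a gap beyond the scatter. Compound 3 (`Cc1nc(C)c(COC(=O)N[C@H](CC(C)C)C(=O)Oc2ccc(-c3cc(=O)c4c(O)c(O)c(O)cc4o3)cc2)nc1C`) is still unmeasured. It has isobutyl in place of isopropyl on a saturated chain carbon bound to an amide-type nitrogen and a carbonyl carbon. Compound 1 also carries isobutyl and sits at 26 ug/mL on the lower side, though it differs from compound 2 elsewhere too. A modest drop in this assay is expected, estimated as a 2.8-fold lower number from compound 2 to compound 3 (0.45 log units; beyond the scatter) in size and just beyond the scatter. Compound 3 is estimated at 90 ug/mL with an expected range from 30 ug/mL to 260 ug/mL in this measurement.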

Compound 3, solubility: 221 ug/mL
Estimate against measurement, compound 3: 2.5-fold (0.39 log units) below, and the stated range covers the measured number.
By their numbers in this assay, from the lowest: compound 1; then compounds 3 and 2 (each within the scatter of the next).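

In this assay, isobutyl in place of isopropyl on a saturated chain carbon bound to an amide-type nitrogen and a carbonyl carbon gives a 1.1-fold lower number from compound 2 to compound 3 (0.06 log units; within the scatter), so this change leaves no readable difference. By contrast, (3,5,6-trimethylpyrazin-2-yl)methoxy in place of 3,5,6-trimethylpyrazin-2-yl on a carbonyl carbon, with isobutyl kept, gives an 8.5-fold higher number from compound 1 to compound 3 (0.93 log units; beyond the scatter). Nothing available here accounts for either step. From the compounds shown here alone, how an amine, a carboxylic acid or a longer chain at that chain carbon would behave stays open.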